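A Hydroxy Group Joins the 3-Chlorophenyl Ring

The compounds below may be only part of what the source reports. "The series", "measured", "known", "first", "only" and "open" are said of these compounds alone.

Measured compounds:
compound 1, `COc1ccccc1/C=C1\CCC/C(=C\c2cccc(OC)c2OC)C1=O`: 12000 nM
compound 2, `COc1ccc(/C=C2\CCC/C(=C\c3cccc(Cl)c3)C2=O)cc1OC`: 6000 nM

Both compounds were tested in a functional assay on MCF7 cells (Homo sapiens) for cytotoxicity, read by MTT assay, with a stated time of 72 h; a higher number here means a weaker inhibitor, a lower number a stronger inhibitor. Among the compounds with values here, compound 2 gives the smaller of the two numbers, but its only neighbour, compound 1, sits within the scatter of repeated measurement, so the two cannot be separated on these data alone.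

Compound 3, `COc1ccc(/C=C2\CCC/C(=C\c3ccc(O)c(Cl)c3)C2=O)cc1OC`, has not yet been measured. It differs from compound 2 in one place: hydroxy in place of hydrogen on an aromatic carbon. The change turns the 3-chlorophenyl group into a 3-chloro-4-hydroxyphenyl group, a small addition that brings one hydrogen-bond donor and one acceptor.

Within the data shown here, with no measured step of this kind to lean on, the expected step from compound 2 to compound 3 in this assay is a 1.2-fold lower number from compound 2 to compound 3 (0.08 log units; within the scatter), a change no larger than the scatter. Compound 3 is therefore estimated at 5000 nM, with a range from 1500 nM to 15000 nM.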

Compound 3, half-maximal inhibitory concentration: 12300 nM
Estimate against measurement, compound 3: 2.5-fold (0.39 log units) below; the range from low to high includes it.
By their numbers in this assay, from the lowest: compounds 2, 1 and 3 (each within the scatter of the next, the first and the last beyond it).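

In this assay there is a 2.1-fold higher number from compound 2 to compound 3 (0.31 log units; beyond the scatter) when hydroxy takes the place of hydrogen on the 3-chlorophenyl ring. This aromatic carbon, ortho to a chloro group and para to a large group, therefore responds to substitution, and here the added hydroxy goes with a weaker inhibitor, not a stronger one. The step is modest, and no measurement at hand accounts for it.

Still open, going by these compounds, is whether this weakening is specific to the hydroxy group or would also appear with another group on the same carbon, such as an amine or a carboxylic acid. A single step also cannot show whether hydroxy would have the same effect on a ring without the chloro group.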